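Thiophen-2-yl in place of 4-methylphenyl on a sulfonamide

A few compounds are considered here, and "the series" means these few. Any claim that something is new, unique, unknown or untested is made for them only; others in the source may bear on it.

In a functional assay on A-431 cells (Homo sapiens) for cytotoxicity, read by MTT assay, with a stated time of 48 h (on this read-out lower numbers stand for stronger inhibition and higher numbers for weaker inhibition), compound 2 `CCCCCCCCCCCCNC(=O)[C@@H](NS(=O)(=O)c1ccc(C)cc1)[C@@H](C)O` gives 25200 nM. Compound 1 `CCCCCCCCCCCCNC(=O)[C@@H](NC(=O)c1ccccc1)[C@@H](C)O` gives 41200 nM. Compound 2 thus holds the smaller of the two numbers, but the step of a 1.6-fold lower number from compound 1 to compound 2 (0.21 log units; within the scatter) is within the scatter, so the two cannot be told apart. Compound 3 `CCCCCCCCCCCCNC(=O)[C@@H](NS(=O)(=O)c1cccs1)[C@@H](C)O` differs from compound 2 by thiophen-2-yl in place of 4-methylphenyl on a sulfonyl sulfur. Among the measured compounds shown here, no measured step touches this position; the only step seen exchanged benzoyl for (4-methylphenyl)sulfonyl on the amine nitrogen and was small. A change beyond the scatter is therefore not expected, and the estimated step is a 1.2-fold higher number from compound 2 to compound 3 (0.08 log units; within the scatter). Compound 3 is expected at 30000 nM, within 12000 nM to 75000 nM.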

Compound 3, half-maximal inhibitory concentration: 22000 nM
Compound 3: the middle estimate sits 1.4-fold (0.13 log units) above what was measured; the range from low to high includes it.
By their numbers in this assay, from the lowest: compounds 3, 2 and 1 (each within the scatter of the next).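

Placing thiophen-2-yl on the sulfonyl sulfur gives a 1.1-fold lower number from compound 2 to compound 3 (0.06 log units; within the scatter) in this assay and shows that a five-membered aromatic ring containing sulfur can replace 4-methylphenyl here without a change distinguishable from the scatter. The wider exchange gives a 1.9-fold lower number from compound 1 to compound 3 (0.27 log units; within the scatter) and also stays within the scatter, so (thiophen-2-yl)sulfonyl cannot be separated from benzoyl on the amine nitrogen. Nothing available explains these results. On these data alone, it remains open how an amine or a carboxylic acid on the sulfonyl sulfur would read in this assay.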